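This account rests on a few compounds, and the source may have more. Where it says the series, first, only, none or still open, it means among the compounds named here.

Measured so far in an ADME assay on HEK293 cells (Homo sapiens) for cytotoxicity, read by luminescence, with a stated time of 72 h; on this read-out lower numbers stand for an effect already at smaller amounts and higher numbers for an effect only at larger amounts of compound

Compound 1 (`CCOC(=O)c1c(-c2cccc(Cl)c2)[nH]c2cc(OC)ccc2c1=O`) gives the limit > 22000 nM
Compound 2 (`CCOC(=O)c1c(-c2cccc(Br)c2)[nH]c2cc(OC)ccc2c1=O`) gives the limit > 22000 nM

Compound 2 stands at the limit > 22000 nM and not at a number. For the measured compounds named here, the one measured step is a step that the two limits leave unreadable from compound 1 to compound 2 and so offers no size to carry over, and the record holds only (the limit of > 22000 nM in this assay, at which 2 of the 2 values shown sit). Compound 3 (`CCOC(=O)c1c(-c2cccc(C(C)=O)c2)[nH]c2cc(OC)ccc2c1=O`) carries acetyl in place of bromo on an aromatic carbon. With compound 2 at its limit of > 22000 nM as the only anchor, no step beyond the scatter is expected in this assay in either direction. The expected change is (a number no higher from compound 2 to compound 3 (the limit leaves the size open)). Compound 3 is expected near 22000 nM (estimated range 12000 nM to 40000 nM).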

Compound 3, half-maximal effective concentration: > 22000 nM
Compound 3 ended at the assay's limit; the forecaster's own chance of this, stated with the estimate: 80%; the middle value lies on the limit itself.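

No step between compound 1, compound 2 and compound 3 can be read, since each gives a limit and not a number: the limit of > 22000 nM in this assay, at which 3 of the 3 values shown sit.

The compounds shown leave open whether any group in that place would bring a measurable value.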